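A few compounds are considered here, and "the series" means these few. Any claim that something is new, unique, unknown or untested is made for them only; others in the source may bear on it.

Measured in a functional assay on HOS-TE85 cells (Homo sapiens) for inhibition, read by CCK-8 assay, with a stated time of 72 h; on this read-out higher numbers stand for weaker inhibition and lower numbers for stronger inhibition:
- Compound 1 `COc1ccc(OC)c(N2C(=O)CSC2c2cccc(C(=O)NCCCCc3ccccc3)c2)c1`: > 1000 nM
- Compound 2 `CC1SC(c2cccc(C(=O)NCCCCc3ccccc3)c2)N(c2ccc(C3CC3)cc2)C1=O`: 191 nM
- Compound 3 `COc1ccccc1N1C(=O)CSC1c1cccc(C(=O)NCCCCn2cncn2)c1`: > 1000 nM

Compound 1 gives > 1000 nM, which is a limit and not a number. It therefore stands at the limit of > 1000 nM in this assay, at which 2 of the 3 values shown sit. Compound 3 gives > 1000 nM, which is also a limit. Only compound 2 has a true number, 191 nM, so a measurable value does occur among these compounds in this assay.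

Compound 4 `COc1ccc(F)cc1N1C(=O)CSC1c1cccc(C(=O)NCCCCc2ccccc2)c1` has not yet been measured. Its structural change from compound 1 is fluoro in place of methoxy on an aromatic carbon. In words, fluoro takes the place of methoxy on an aromatic carbon, meta to a large group and para to a methoxy group, so that 2,5-dimethoxyphenyl becomes 5-fluoro-2-methoxyphenyl.

Among the compounds with values here, no measured pair shows what this exchange does, so any expectation here is loose. The starting point is compound 1 at > 1000 nM, and a single small exchange is not expected to move far from it. The expected step of an at least 1.1-fold lower number from compound 1 to compound 4 (0.04 log units; that floor lies within the scatter) is modest, towards stronger inhibition if it moves at all, and it may stay within the usual scatter. For compound 4 the estimated value is 900 nM, with an expected range of 300 nM to 2500 nM.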

Compound 4, half-maximal inhibitory concentration: 8.8 nM
Compound 4: middle estimate off by 100-fold (2.01 log units), on the high side; measured number below the stated range.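

In this assay, putting fluoro in place of methoxy, so that 2,5-dimethoxyphenyl becomes 5-fluoro-2-methoxyphenyl, gives an at least 110-fold lower number from compound 1 to compound 4 (2.05 log units; beyond the scatter) and thus turns a compound with no measured potency into one with a true number. Compound 1 stands at a limit and not at a number, so the real step could be larger still: the limit of > 1000 nM in this assay, at which 2 of the 4 values shown sit. Within the data shown here, the earlier compounds held no pair differing in one place, and this pair is the first to show that the group at this aromatic carbon, meta to a large group and para to a methoxy group, can matter a great deal.

This single pair cannot separate the effect of removing methoxy from that of adding fluoro, and it gives no cause for the step. It also leaves open how other groups would behave at this place, such as chloro, a methyl group or an amine, and whether the same exchange would have a similar effect in a compound carrying the chain of compound 3.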